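Adding a Third Methoxy Group to Compound 2

The source may report more compounds than this note shows. Statements on the series, on what has been measured and on what is new or still open speak of the compounds shown alone.

Compound 1 `COc1ccc(/C=C/C2CC(=O)C=CO2)cc1` in a functional assay on 786-0 cells (Homo sapiens) for inhibition, read by sulforhodamine B assay, with a stated time of 48 h; a lower number here means a stronger inhibitor of growth, a higher number a weaker inhibitor of growth: compound 1 gives 192 uM
Compound 2 `COc1ccc(/C=C/C2CC(=O)C=CO2)cc1OC` in this assay: compound 2 gives 145 uM

Within the data shown here, compound 2 shows the lowest of the two numbers in this assay, but the only measured step, a 1.3-fold lower number from compound 1 to compound 2 (0.12 log units; within the scatter), lies within the scatter, so the two compounds cannot be ranked against each other. Compound 3 `COc1cc(/C=C/C2CC(=O)C=CO2)cc(OC)c1OC` differs from compound 2 by methoxy in place of hydrogen on an aromatic carbon. Among the measured compounds shown here, the one measured step that bears on this change is a 1.3-fold lower number from compound 1 to compound 2 (0.12 log units; within the scatter), which is itself a methoxy in place of hydrogen on an aromatic carbon and stayed within the scatter. On that basis no step beyond the scatter is expected in this assay for compound 3 in either direction. Compound 3 is therefore estimated at 130 uM, with a range from 60 uM to 300 uM, which amounts to an expected step of a 1.1-fold lower number from compound 2 to compound 3 (0.05 log units; within the scatter).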

Compound 3, concentration for growth inhibition (reported as GI): 125 uM
Compound 3: the middle estimate sits 1.0-fold (0.02 log units) above what was measured; the range from low to high includes it.
By their numbers in this assay, from the lowest: compounds 3, 2 and 1 (each within the scatter of the next).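

In this assay, the second replacement of hydrogen by methoxy, a 1.2-fold lower number from compound 2 to compound 3 (0.06 log units; within the scatter), stays within the scatter, as the first did. This time the methoxy sits on an aromatic carbon ortho to a methoxy group and meta to a group of 9 heavy atoms, so the same change at this further place gives no difference that can be read. Nothing shown here bears on why this is so.

The compounds shown leave open whether a hydroxyl or an amine on this aromatic carbon, in place of the methoxy, would give a step beyond the scatter. They also leave open whether any change to the shared core, rather than to the aromatic ring, would move the number further than these methoxy steps did.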